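The source may report more compounds than this note shows. Statements on the series, on what has been measured and on what is new or still open speak of the compounds shown alone.

Compound 1, `CCCN(CCCCCCc1ccc(O)c(OC)c1)C1CCc2nc(N)sc2C1`: 0.675 nM
Compound 2, `CCCN(CCCc1ccc(O)c(O)c1)C1CCc2nc(N)sc2C1`: 11.9 nM
Compound 3, `CCCN(CCCCCc1cc(O)ccc1O)C1CCc2nc(N)sc2C1`: 1.01 nM

All three were tested in an assay on HEK293 cells for displacement of a labelled ligand from D(3) dopamine receptor (Rattus norvegicus), with a stated time of 1 h; a lower number here means a stronger inhibitor, a higher number a weaker inhibitor. Compound 2 has the highest number of the three, and the gaps to both compound 1 and compound 3 lie beyond the usual scatter of the measurement, so compound 2 is the weakest binder among them.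

Compound 4, `CCCN(CCCc1ccc(O)c(OC)c1)C1CCc2nc(N)sc2C1`, has not been measured yet. It differs from compound 2 in one place: methyl in place of hydrogen on an oxygen on an aromatic ring. Within the data shown here, no pair of measured compounds differs by only this change, so there is no measured step of this kind to lean on. Compound 1, however, carries the same pair of hydroxy and methoxy groups on its ring and gives 0.675 nM, though it also has a longer chain between the nitrogen and the ring, so it is only a partial guide. A moderate step downward, a 3.0-fold lower number from compound 2 to compound 4 (0.47 log units; beyond the scatter), is expected. Compound 4 is estimated at 4 nM, within a range of 1.2 nM to 15 nM.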

Compound 4, inhibition constant: 15.8 nM
Estimate against measurement, compound 4: 4.0-fold (0.60 log units) below, outside the stated range (above it).
By their numbers in this assay, from the lowest: compounds 1 and 3 (each within the scatter of the next); then compounds 2 and 4 (each within the scatter of the next).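

In this assay, the change from hydroxy to methoxy on this oxygen on the aromatic ring gives a 1.3-fold higher number from compound 2 to compound 4 (0.12 log units; within the scatter). Among these compounds, this is the first direct reading of that change, and with the chain of compound 2 and compound 4 the extra methyl makes no difference this assay can resolve, so a free hydroxy at this place is not needed for binding at this level. The methoxy alone also does not bring compound 4, at 15.8 nM, to the number of compound 1 (0.675 nM), which carries the same ring groups on a longer chain.

Nothing given here explains why the change leaves the number where it is. Still open, going by these compounds, is whether a larger group on this oxygen, such as ethoxy or benzyloxy, would be accepted as well, and whether an amine at this place would behave like the hydroxy.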